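The source may report more compounds than this note shows. Statements on the series, on what has been measured and on what is new or still open speak of the compounds shown alone.

The series shares one core, carried by compound 1 `O=C(O)/C=C/C(=O)Nc1cccc(-c2nc3ccccc3s2)c1`, compound 2 `O=C(Nc1cccc(-c2nc3ccccc3s2)c1)c1cccnc1Cl` and compound 3 `O=C(Nc1cccc(-c2nc3ccccc3s2)c1)c1ccncc1Cl`, and all three were tested in an ADME assay on BJ cells (Homo sapiens) for inhibition, with a stated time of 72 h; a higher number here means that more compound is needed for the effect, a lower number that less compound is needed. In this assay compound 1 reaches only the limit of the test, > 25000 nM. Compound 2 likewise gives only a limit, > 25000 nM. Compound 3 also stops at a limit, > 25000 nM. Compound 2 therefore stands nowhere that can be placed on a scale: with every value a limit, (the limit of > 25000 nM in this assay, at which 3 of the 3 values shown sit), no number is known for it. The step that the two limits leave unreadable from compound 1 to compound 2 cannot be read, nor can a step that the two limits leave unreadable from compound 1 to compound 3 or a step that the two limits leave unreadable from compound 2 to compound 3, since two limits give no size between them.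

Compound 4 `O=C(Nc1cccc(-c2nc3ccccc3s2)c1)c1cc([N+](=O)[O-])cnc1Cl` differs from compound 2 in one place: nitro in place of hydrogen on an aromatic carbon. Within the data shown here, none of the measured steps gives a readable size, so they offer no direction for this change; they show only that compound 2 and its neighbours all sit at the limit. The most probable outcome for compound 4 is the same limit again, and the expected step is a number no higher from compound 2 to compound 4 (the limit leaves the size open). Compound 4 is accordingly estimated to give 25000 nM, with a plausible range from 8000 nM to 100000 nM.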

Compound 4, half-maximal effective concentration: > 25000 nM
Compound 4: a limit, no number; the forecaster's own chance of this, stated with the estimate: 80%; the middle value lies on the limit itself.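

In this assay compound 4 gives > 25000 nM, which is a limit and not a number. Compound 2 and compound 4 both stop at a limit, and no size can be read for the step between them: the limit of > 25000 nM in this assay, at which 4 of the 4 values shown sit.

The compounds shown leave open whether nitro in place of hydrogen, or any other change on the shared core, alters the concentration needed for the effect.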